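Swapping the Chlorophenyl Ring of Compound 1 for a Pentyl Chain

A few compounds are considered here, and "the series" means these few. Any claim that something is new, unique, unknown or untested is made for them only; others in the source may bear on it.

Compound 1 `Clc1ccccc1-c1nnc2nnc(N3CCCC3)nn12` was tested in a functional assay on BeWo cells (Homo sapiens) for cytotoxicity, read by MTT assay, with a stated time of 72 h (a higher number here means a weaker inhibitor, a lower number a stronger inhibitor), where compound 1 gives 2990 nM, the lowest of the three numbers measured. Compound 2 `Fc1ccc(-c2nnc3nnc(N4CCCCC4)nn23)cc1` gives 3340 nM in this assay, within the scatter of compound 1, while compound 3 `Clc1ccc(-c2nnc3nnc(N4CCCC4)nn23)c(Cl)c1` gives 8060 nM; the step of a 2.7-fold higher number from compound 1 to compound 3 (0.43 log units; beyond the scatter) accompanies chloro in place of hydrogen on an aromatic carbon. Compound 4 `CCCCCc1nnc2nnc(N3CCCC3)nn12` alters compound 1 in a different way: pentyl in place of 2-chlorophenyl on an aromatic carbon. Going by the values given here, no measured step covers such an exchange of a ring for a chain, and the single step involving a chloro group does not transfer to it, so the expectation rests on little and leans only slightly toward a higher number. Compound 4 is estimated at 5000 nM, within a range from 1500 nM to 17000 nM, an expected step of a 1.7-fold higher number from compound 1 to compound 4 (0.22 log units; within the scatter).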

Compound 4, half-maximal inhibitory concentration: 27900 nM
Estimate against measurement, compound 4: 5.6-fold (0.75 log units) below; measured number above the stated range.
By their numbers in this assay, from the lowest: compounds 1 and 2 (each within the scatter of the next); then compound 3; then compound 4.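

In this assay, the group at this position matters: a 9.3-fold higher number from compound 1 to compound 4 (0.97 log units; beyond the scatter) accompanies pentyl in place of 2-chlorophenyl. Compound 4 is the first compound shown without an aromatic ring here, and its step shows that this exchange goes with clearly weaker inhibition. Nothing measured here explains the change. As far as these compounds go, the change removes both the ring and its chlorine, so their separate contributions remain open. From the compounds shown here alone, it also remains open whether plain phenyl, cyclohexyl or a shorter chain such as propyl would stay closer to compound 1.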